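Swapping the aryl group on the triazole of compound 3

The source may report more compounds than this note shows. Statements on the series, on what has been measured and on what is new or still open speak of the compounds shown alone.

The shared core carries a quinoline-like ether linked through an amide to a triazole bearing an aryl group, with an amine tail. Compound 1 `COc1cc2c(Oc3ccc(NC(=O)c4cn(-c5ccc(F)c(F)c5)nn4)cc3F)ccnc2cc1OCCCN1CCCCC1` gives 310 nM in a functional assay on MKN-45 cells (Homo sapiens) for cytotoxicity, read by MTT assay, with a stated time of 72 h; a higher number here means a weaker inhibitor, a lower number a stronger inhibitor. Compound 2 `COc1cc2c(Oc3ccc(NC(=O)c4cn(-c5ccccc5)nn4)cc3F)ccnc2cc1OCCCN1CCC(C)CC1`, which carries a phenyl on the triazole and a 4-methylpiperidine in the tail, gives 90 nM in this assay. Compound 3 `COc1cc2c(Oc3ccc(NC(=O)c4cn(-c5ccccc5C)nn4)cc3F)ccnc2cc1OCCCN1CCC(C)CC1` carries a 2-methylphenyl on the triazole; in this assay compound 3 gives "not determined" (no result reported), so it stands without a number of its own.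

Compound 4 `COc1cc2c(Oc3ccc(NC(=O)c4cn(-c5ccc(F)c(F)c5)nn4)cc3F)ccnc2cc1OCCCN1CCC(C)CC1` differs from compound 3 by 3,4-difluorophenyl in place of 2-methylphenyl on an aromatic nitrogen. Compound 4 is thus the pairing of the aryl group of compound 1 with the amine tail of compound 2. Among the compounds with values here, no measured pair isolates this exact change, so its size cannot be read off directly; compound 1 and compound 2 differ in two places at once, and their values sit within a modest spread of each other. Within the data shown here, on that basis the expectation for compound 4 is a potency between those of compound 1 and compound 2, with no step clearly beyond the scatter in either direction. Compound 4 is therefore estimated at 160 nM, with a range from 50 nM to 500 nM.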

Compound 4, half-maximal inhibitory concentration: 1290 nM
For compound 4 the middle estimate is 8.1-fold (0.91 log units) below the measured one, and the stated range ends below it.
By their numbers in this assay, from the lowest: compound 2; then compound 1; then compound 4.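

Compound 4 separates two changes that were tangled together in compounds 1 and 2, which differ in two places at once. In this assay, with the 4-methylpiperidine tail held fixed, 3,4-difluorophenyl in place of phenyl on the triazole nitrogen gives a 14-fold higher number from compound 2 to compound 4 (1.16 log units; beyond the scatter), so this aromatic nitrogen position is sensitive to the aryl group it carries, and this difluoro swap costs potency clearly. With the 3,4-difluorophenyl held fixed, methyl in place of hydrogen on a saturated ring carbon of the tail gives a 4.2-fold higher number from compound 1 to compound 4 (0.62 log units; beyond the scatter), so that small addition also weakens the compound, and nothing measured here gives a reason for either loss.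

On these data alone, the step from compound 3 cannot be read, as it has no number of its own, so the effect of the 2-methylphenyl stays unknown beside the plain phenyl of compound 2. The compounds shown also leave open whether a single fluorine, as in 4-fluorophenyl, would carry the same penalty, and how a morpholine tail would behave with either aryl group.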